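Thiourea analogues on liver cancer cells: a halogenated variant

A few compounds are considered here, and "the series" means these few. Any claim that something is new, unique, unknown or untested is made for them only; others in the source may bear on it.

In a functional assay on HepG2 cells (Homo sapiens) for antiproliferative activity, read by MTT assay (on this read-out lower numbers stand for stronger inhibition and higher numbers for weaker inhibition), three compounds have been measured:
Compound 1, `CNC(=O)c1ccc(Oc2cccc(NC(=S)Nc3ccc(C)cc3)c2)nc1`, gives 65400 nM.
Compound 2, `CNC(=O)c1ccc(Oc2cccc(NC(=S)Nc3ccc(Cl)cc3)c2)nc1`, gives 29400 nM.
Compound 3, `CNC(=O)c1ccc(Oc2cccc(NC(=S)Nc3ccc(OC)cc3)c2)nc1`, gives 85300 nM.

Compound 1 stands second highest of these three numbers. Its gap to compound 3 is within the scatter, whereas the other step is beyond it: a 2.2-fold lower number from compound 1 to compound 2 (0.35 log units; beyond the scatter), a modest change. Compound 4, `CNC(=O)c1ccc(Oc2cccc(NC(=S)Nc3ccc(F)c(Cl)c3)c2)nc1`, differs from compound 1 by 3-chloro-4-fluorophenyl in place of 4-methylphenyl on an amide-type nitrogen. Going by the values given here, the only measured step that bears on this is the chloro-for-methyl exchange, a 2.2-fold lower number from compound 1 to compound 2 (0.35 log units; beyond the scatter), since compound 4 also carries chloro, with fluorine added. A lowering of about that size is therefore expected for compound 4, a 2.5-fold lower number from compound 1 to compound 4 (0.40 log units; beyond the scatter). Compound 4 is estimated at 26000 nM, with a range from 10000 nM to 65000 nM.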

Compound 4, half-maximal inhibitory concentration: > 100000 nM
Compound 4 was reported as a limit (the forecaster's own chance of this, stated with the estimate: 5%); at least 3.8-fold (0.58 log units) between middle value and limit.
By their numbers in this assay, from the lowest: compound 2; then compounds 1 and 3 (each within the scatter of the next). At a limit, above all of these: compound 4.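

In this assay compound 4 appears only as a limit: the limit of > 100000 nM in this assay, at which 1 of the 4 values shown sits. On this amide-type nitrogen, then, a chlorine-bearing ring does not by itself bring the lower number of compound 2, since 3-chloro-4-fluorophenyl goes the other way, with an at least 3.4-fold higher number from compound 2 to compound 4 (0.53 log units; beyond the scatter). Against the other two compounds only floors can be read, and both lie within the scatter: an at least 1.5-fold higher number from compound 1 to compound 4 (0.18 log units; that floor lies within the scatter), and an at least 1.1-fold higher number from compound 3 to compound 4 (0.06 log units; that floor lies within the scatter).

The compounds shown leave open how far the fluorine alone accounts for this step. On these data alone, how a ring bearing an amine or a carboxylic acid would read also stays open.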